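Swapping a Nitro for a Thiazole: Expected Solubility

The compounds below may be only part of what the source reports. "The series", "measured", "known", "first", "only" and "open" are said of these compounds alone.

Among the compounds with values here, compound 1 `NC(=O)c1ccc(-c2cc(-c3ccc([N+](=O)[O-])cc3)nc(-c3ccco3)c2)cc1` gives 8000 nM in a physicochemical assay for solubility, at pH 6 (a lower number here means a less soluble compound, a higher number a more soluble compound), the lower of the two numbers measured so far. Compound 2 `Cn1nncc1-c1cc(-c2ccc(C(N)=O)cc2)cc(-c2ccc(C#N)cc2)n1` gives 32000 nM in this assay, a gap from compound 1 that lies beyond the usual scatter. Compound 3 `NC(=O)c1ccc(-c2cc(-c3ccc(-c4nccs4)cc3)nc(-c3ccco3)c2)cc1` differs from compound 1 in one place: 1,3-thiazol-2-yl in place of nitro on an aromatic carbon. Within the data shown here, no measured pair shows this change, so only a modest downward step is expected from compound 1 to compound 3, a 1.6-fold lower number from compound 1 to compound 3 (0.20 log units; within the scatter). Compound 3 is therefore estimated at 5000 nM, within a range from 1500 nM to 16000 nM.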

Compound 3, solubility: 125000 nM
The estimate for compound 3 lay 25-fold (1.40 log units) below the measured number, outside the stated range (above it).
By their numbers in this assay, from the lowest: compound 1; then compound 2; then compound 3.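

In this assay, 1,3-thiazol-2-yl in place of nitro on this aromatic carbon, para to a large group, gives a 16-fold higher number from compound 1 to compound 3 (1.19 log units; beyond the scatter). Within the data shown here, the two earlier compounds differ in more than one place, so only this pair shows that the read-out responds strongly to a single change at this position. No measurement shown here accounts for the size of the step.

Going by these compounds, it remains open whether the step reflects the arrival of the thiazole or the departure of the nitro, and what an amine or a carboxylic acid here would give. On these data alone, whether the same change would give a similar step on another core also remains open.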